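Methyl on the pyridine ring of the morpholine thiosemicarbazide series

A few compounds are considered here, and "the series" means these few. Any claim that something is new, unique, unknown or untested is made for them only; others in the source may bear on it.

Measured so far:
compound 1 `Cc1ccnc(/C(N)=N/NC(=S)N2CCCC2)c1` — 58.5%
compound 2 `N/C(=N\NC(=S)N1CCOCC1)c1ccc(F)cn1` — 31.8%
compound 3 `N/C(=N\NC(=S)N1CCOCC1)c1ccccn1` — 29.2%

In a functional assay on A-431 cells (Homo sapiens) for cytotoxicity, read by MTT assay, with a stated time of 72 h, tested at 1 uM (on this read-out lower numbers stand for less inhibition of growth and higher numbers for more inhibition of growth at the one concentration tested), compound 3 gives 29.2%, the lowest of the three numbers; compound 2 lies within the scatter of it, compound 1 beyond it. Among the compounds with values here, the one measured step, a number 2.6 percentage points lower from compound 2 to compound 3 (within the scatter), changes a different group (hydrogen in place of fluoro) and so bears only indirectly on the next change. Compound 4 `Cc1ccnc(/C(N)=N/NC(=S)N2CCOCC2)c1` differs from compound 3 as follows: methyl in place of hydrogen on an aromatic carbon. Within the data shown here, compound 1 also carries this methyl and shows the high number, but it differs from compound 3 in two places, so no single step isolates the methyl. Given that, compound 4 is expected to rise modestly, a number 8.8 percentage points higher from compound 3 to compound 4 (within the scatter), with wide uncertainty. The estimate for compound 4 is 38%, between 22% and 56%.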

Compound 4, percent growth inhibition at one concentration: 33.6%
Beside the measured number, compound 4's estimate is 4.4 percentage points above it, and the stated range covers the measured number.
By their numbers in this assay, from the lowest: compounds 3, 2 and 4 (each within the scatter of the next); then compound 1.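

In this assay methyl in place of hydrogen opposite the ring nitrogen gives a number 4.4 percentage points higher from compound 3 to compound 4 (within the scatter) and so does not by itself account for the high number of compound 1. With the methyl present in both, morpholin-4-yl in place of pyrrolidin-1-yl on the thiocarbonyl carbon gives a number 24.9 percentage points lower from compound 1 to compound 4 (beyond the scatter) and is the only single change shown that lies beyond the scatter. No measured evidence bears on the reason for either step.

Open, from the compounds shown here alone, is whether a pyrrolidin-1-yl compound with hydrogen in place of the methyl keeps the higher number. Also open, going by these compounds, is how an amine or a methoxy group would read at this ring position.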